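The source may report more compounds than this note shows. Statements on the series, on what has been measured and on what is new or still open speak of the compounds shown alone.

Going by the values given here, compound 2 `COc1ccc(-c2ncnn2-c2cc(OC)c(OC)c(OC)c2)cc1` is the one member of this small set that gives a measured number in a functional assay on Jurkat cells (Homo sapiens) for antiproliferative activity, read by MTT assay, with a stated time of 72 h; a lower number here means a stronger inhibitor, a higher number a weaker inhibitor: in this assay compound 2 gives 50 nM. Among the compounds with values here, compound 1 `COc1cc(-c2ncnn2-c2ccc(Cl)cc2Cl)cc(OC)c1OC` gives only a limit in this assay, > 10000 nM, and stands at the limit of > 10000 nM in this assay, at which 1 of the 2 values shown sits, so compound 2 is the only compound here with a number rather than a limit.

Compound 3 `COc1cc(-n2ncnc2-c2ccc(SC)cc2)cc(OC)c1OC` has not yet been measured. It differs from compound 2 in one place: methylsulfanyl in place of methoxy on an aromatic carbon.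

Within the data shown here, no measured pair in this set shows what such an exchange does in this assay, so the expectation for compound 3 rests on compound 2 alone. The change is small in size, and the step from compound 2 to compound 3 is expected to be modest, a 1.2-fold higher number from compound 2 to compound 3 (0.08 log units; within the scatter), with no clear direction beyond the usual scatter of repeated measurements. On that basis compound 3 is estimated to give 60 nM in this assay, with the likely range running from 20 nM to 200 nM.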

Compound 3, half-maximal inhibitory concentration: 50 nM
For compound 3 the middle estimate is 1.2-fold (0.08 log units) above the measured one; low and high end bracket the measured number.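

In this assay, going by these compounds alone, the exchange of 4-methoxyphenyl for 4-(methylsulfanyl)phenyl gives no change at the digits printed from compound 2 to compound 3 (within the scatter), and this is the first step in the set that can be read. At this position, para to a large group, a sulfur atom can therefore take the place of the oxygen of the methoxy group with no loss of activity in this assay, although this rests on a single pair of compounds. Nothing measured here explains why the two groups give the same reading, and no cause can be assigned to the result.

The compounds shown leave open how much room there is for other groups at this position, such as a hydroxyl, an amine, a carboxylic acid or a longer chain like butoxy, any of which would test the limits of what the position accepts. They also leave open whether the same exchange would read the same way on a core carrying a different aromatic ring.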